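Trimming a Fused Ring from a Ubiquitin Hydrolase Inhibitor

The source may report more compounds than this note shows. Statements on the series, on what has been measured and on what is new or still open speak of the compounds shown alone.

Compound 1 `Cc1cc(Cl)cc(-c2ccnc3cc(CN4C(=O)C5CC5C4=O)sc23)c1O[C@@H]1CCNC[C@@H]1C` was tested in an assay on RKO cells for inhibition of ubiquitin carboxyl-terminal hydrolase 7 (Homo sapiens), read by a luciferase reporter, with a stated time of 18 h (a lower number here means that less compound is needed, a higher number that more compound is needed for the effect), and gave 170 nM. Of the two compounds measured, compound 1 has the higher number; compound 2 `Cc1cc(Cl)cc(-c2ccnc3cc(CN4C(=O)C5C(C4=O)C5(C)C)sc23)c1C[C@@H]1CNCCO1` in this assay gives 25 nM, a gap beyond the usual scatter. Compound 3 `Cc1cc(Cl)cc(-c2ccnc3cc(CN4C(=O)CCC4=O)sc23)c1O[C@@H]1CCNC[C@@H]1C` has not yet been measured. It differs from compound 1 in one place: a group of 7 heavy atoms (4 carbon, 1 nitrogen, 2 oxygen; one five-membered non-aromatic ring with 1 hetero atom) in place of a group of 8 heavy atoms (5 carbon, 1 nitrogen, 2 oxygen; one three-membered non-aromatic ring of carbon only, one five-membered non-aromatic ring with 1 hetero atom), on a saturated chain carbon bound to an aromatic carbon The three-membered ring of carbon only is thus dropped, leaving the plain 2,5-dioxopyrrolidin-1-yl group on the same saturated chain carbon. For the measured compounds named here, no step between measured compounds matches this change, so the expectation rests on compound 1 alone, starting from its 170 nM in this assay. A modest move toward a higher number is expected, at about the edge of the scatter. Compound 3 is estimated at 320 nM, within a range from 110 nM to 950 nM. The expected step is a 1.9-fold higher number from compound 1 to compound 3 (0.27 log units; within the scatter).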

Compound 3, half-maximal effective concentration: 150 nM
Estimate against measurement, compound 3: 2.1-fold (0.33 log units) above; low and high end bracket the measured number.
By their numbers in this assay, from the lowest: compound 2; then compounds 3 and 1 (each within the scatter of the next).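

In this assay, dropping the three-membered ring of carbon only and leaving the plain 2,5-dioxopyrrolidin-1-yl group on the saturated chain carbon gives a 1.1-fold lower number from compound 1 to compound 3 (0.05 log units; within the scatter), so this ring can go without a change that stands out from the scatter. This is a cleaner reading than compound 1 against compound 2 could give, since those two differ in more than one place. Nothing at hand explains why removing the ring leaves the number within the scatter.

Still open, from the compounds shown here alone, is what happens when an amine, a carboxylic acid or an open-chain amide replaces the 2,5-dioxopyrrolidin-1-yl group on this carbon. Also open, going by these compounds, is what the two methyl groups on the three-membered ring of compound 2 contribute on their own, as that compound differs from compound 1 elsewhere too.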